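A few compounds are considered here, and "the series" means these few. Any claim that something is new, unique, unknown or untested is made for them only; others in the source may bear on it.

Of the compounds shown here, three have been measured in a functional assay on MOLT-4 cells (Homo sapiens) for antiproliferative activity, read by MTT assay, with a stated time of 72 h; a lower number here means a stronger inhibitor, a higher number a weaker inhibitor. Compound 1 `O=C1NC(=S)S/C1=C\C1=Cc2cc(Br)ccc2OC1` gives 38200 nM. Compound 3 `CC1Oc2ccc(Br)cc2C=C1/C=C1\SC(=S)NC1=O` gives 20500 nM. The two differ by methyl in place of hydrogen on a saturated ring carbon and the step of a 1.9-fold lower number from compound 1 to compound 3 (0.27 log units; within the scatter) lies within the scatter, so the two numbers cannot be told apart with confidence. Compound 2 `O=C1NC(=O)/C(=C/C2=Cc3cc(Br)ccc3OC2)N1` gives 77500 nM, the highest of the three numbers; how its core differs from that of compound 1 is not broken down here.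

Compound 4 `CC1Oc2ccc(Br)cc2C=C1/C=C1\NC(=O)NC1=O` has not yet been measured. It differs from compound 2 by methyl in place of hydrogen on a saturated ring carbon, the same kind of change as that from compound 1 to compound 3, made at the same place. Because the earlier step of a 1.9-fold lower number from compound 1 to compound 3 (0.27 log units; within the scatter) was small, a step of similar size is expected here, estimated as a 1.8-fold lower number from compound 2 to compound 4 (0.27 log units; within the scatter). On that basis compound 4 is expected to give about 42000 nM in this assay, with a likely range from 20000 nM to 90000 nM. This expectation rests on a single measured pair, so it is held loosely.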

Compound 4, half-maximal inhibitory concentration: 24800 nM
The estimate for compound 4 lay 1.7-fold (0.23 log units) above the measured number; low and high end bracket the measured number.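

Within this assay the methyl in place of hydrogen on a saturated ring carbon gives a 3.1-fold lower number from compound 2 to compound 4 (0.49 log units; beyond the scatter) and so counts as a modest step on this core. Two pairs of compounds cannot show that the same step would appear on any further core, and they say nothing about why the number moves. What they do show is that the size of the step cannot be told apart between these two cores, so the change carries over from one to the other as far as these data can tell: the same change on two cores in this assay, a 1.9-fold lower number (0.27 log units; within the scatter) from compound 1 to compound 3 and a 3.1-fold lower number (0.49 log units; beyond the scatter) from compound 2 to compound 4, 1.7-fold (0.22 log units) apart, within the scatter of two such steps

The compounds shown leave open whether anything other than methyl at this ring carbon would move the number further, for instance an ethyl group, a longer chain, an amine or a carboxylic acid. They also leave open whether the same step would hold if the bromine on the shared core were replaced by another group, such as chlorine or a methoxy group.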